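The source may report more compounds than this note shows. Statements on the series, on what has been measured and on what is new or still open speak of the compounds shown alone.

Measured compounds:
compound 1 `COC(=O)c1cccc(-c2ccc([C@H]3S[C@@H](C)C(=O)Nc4c3c(C)nn4-c3ccccc3C)cc2)c1`: "not active" (no number reported)
compound 2 `Cc1nn(-c2ccccc2Cl)c2c1C(c1ccc(Oc3ccccc3)cc1)SC(C)C(=O)N2`: 2700 nM
compound 3 `Cc1cccc(-n2nc(C)c3c2NC(=O)[C@H](C)S[C@@H]3c2ccc(Oc3ccccc3)cc2)c1`: 2400 nM

All three were tested in an assay on isolated protein for agonist activity at Bile acid receptor (Homo sapiens), read by AlphaScreen, with a stated time of 30 min; on this read-out higher numbers stand for an effect only at larger amounts of compound and lower numbers for an effect already at smaller amounts. Compound 1 gives only the outcome "not active" (no number reported), with no number reported, so it cannot be placed on the scale on which compound 2 gives 2700 nM and compound 3 gives 2400 nM; those two values lie within the scatter of each other. Compound 4 `Cc1ccccc1-n1nc(C)c2c1NC(=O)[C@H](C)S[C@@H]2c1ccc(Oc2ccccc2C(=O)O)cc1` differs from compound 1 by 2-carboxyphenoxy in place of 3-(methoxycarbonyl)phenyl on an aromatic carbon. Among the measured compounds shown here, no measured step covers this change, and with no number for compound 1 no direction or size of step can be stated against it. Compound 4 resembles compound 2 and compound 3 more closely than compound 1 does, so a measurable value in this assay is expected. For compound 4 a value near 1500 nM is estimated, within the range 300 nM to 8000 nM.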

Compound 4, half-maximal effective concentration: "not active" (no number reported)
For compound 4 the study gives words and no number; no gap can be computed for the estimate.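

Compound 1 and compound 4 are both reported without a number, so no step can be read between them, and nothing measured here accounts for this outcome. The compounds shown leave open whether swapping 3-(methoxycarbonyl)phenyl for 2-carboxyphenoxy alone changes the result.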